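Changing the benzyl group: from compound 3 to compound 4

This account rests on a few compounds, and the source may have more. Where it says the series, first, only, none or still open, it means among the compounds named here.

Measured in a functional assay, read by spectrophotometry, with a stated time of 30 min; on this read-out lower numbers stand for stronger inhibition and higher numbers for weaker inhibition:
- Compound 1 `CC(C)(C)c1cc(/C=C/C(=O)NCC2CCN(Cc3ccccc3)CC2)cc(C(C)(C)C)c1O`: 75600 nM
- Compound 2 `Cc1ccccc1CN1CCC(CCNC(=O)/C=C/c2cc(C(C)(C)C)c(O)c(C(C)(C)C)c2)CC1`: 65300 nM
- Compound 3 `CC(C)(C)c1cc(/C=C/C(=O)NCCC2CCN(Cc3ccc(F)cc3F)CC2)cc(C(C)(C)C)c1O`: 62400 nM

The value of compound 3, 62400 nM, lies within the scatter of the values of compound 1 and compound 2, so all three read alike. The unmeasured compound 4 `CC(C)(C)c1cc(/C=C/C(=O)NCCC2CCN(Cc3ccc(C#N)cc3)CC2)cc(C(C)(C)C)c1O` carries one change: 4-cyanophenyl in place of 2,4-difluorophenyl on a saturated chain carbon bound to an amine nitrogen in a ring. Put simply, 4-cyanophenyl stands in place of 2,4-difluorophenyl. Within the data shown here, only one measured step touches this same place: a 1.0-fold lower number from compound 2 to compound 3 (0.02 log units; within the scatter). One step is thin evidence, and no nitrile has been measured in this set. Still, no step beyond the scatter is expected in this assay, and the estimate is a 1.0-fold lower number from compound 3 to compound 4 (0.02 log units; within the scatter). For compound 4 the expected value is 60000 nM, with an estimated range of 30000 nM to 110000 nM.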

Compound 4, half-maximal inhibitory concentration: 79500 nM
For compound 4 the middle estimate is 1.3-fold (0.12 log units) below the measured one; the range from low to high includes it.
By their numbers in this assay, from the lowest: compounds 3, 2, 1 and 4 (each within the scatter of the next).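

In this assay, swapping in 4-cyanophenyl gives a 1.3-fold higher number from compound 3 to compound 4 (0.11 log units; within the scatter) and a 1.2-fold higher number from compound 2 to compound 4 (0.09 log units; within the scatter) at this place, on a saturated chain carbon bound to an amine nitrogen in a ring. Across compound 2, compound 3 and compound 4, a nitrile, with its hydrogen-bond acceptor, therefore reads like the methyl and fluorine groups on the phenyl ring. No measurement shown explains this flat result. Still open, on these data alone, is whether an amine or a carboxylic acid on that phenyl ring would shift the number beyond the scatter.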